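Inverting the stereocentre in a diaryl urea series

This account rests on a few compounds, and the source may have more. Where it says the series, first, only, none or still open, it means among the compounds named here.

Measured compounds and their values:
compound 1, `CC(C)c1ccccc1NC(=O)N[C@@H](C)c1ccccc1`, 99%
compound 2, `COc1ccccc1NC(=O)N[C@@H](C)c1ccccc1`, 98%
compound 3, `C[C@@H](NC(=O)Nc1ccccc1I)c1ccccc1`, 100%

The three compounds share a urea core carrying a phenyl-bearing saturated chain carbon. In an ADME assay on the whole organism with Oryza sativa as the target, tested at 0.1 uM (on this read-out higher numbers stand for a weaker effect at the one concentration tested and lower numbers for a stronger effect), compound 1 gives 99%, and compound 2 gives 98%. Going by the values given here, the single one-place step measured, a number 1 percentage points lower from compound 1 to compound 2 (within the scatter), is within the scatter. Compound 3 gives 100%, and its differences to both compound 1 and compound 2 are also within the scatter, so the three numbers cannot be ordered.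

Compound 4, `C[C@H](NC(=O)Nc1ccccc1I)c1ccccc1`, is not yet measured. It differs from compound 3 in that (the two compounds have the same atoms and bonds and differ only in configuration as drawn: 1 of 1 stereo elements differ; a stereocentre at a saturated chain carbon is drawn R in compound 3 and S in compound 4). Among the compounds with values here, none of the measured steps concerns a change of configuration, so no measured step bears directly on this one; the only measured step, from compound 1 to compound 2, is itself within the scatter. Because compound 3 gives 100% and all three measured numbers sit close together, the step of a number 2 percentage points lower from compound 3 to compound 4 (within the scatter) is expected to remain within the scatter. Compound 4 is therefore estimated at 98%, with a range from 88% to 100%.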

Compound 4, a percentage reported as activity, at one concentration (the size of the read-out at that concentration, not a potency): 99%
Compound 4: the middle estimate sits 1 percentage points below what was measured, and the stated range covers the measured number.
By their numbers in this assay, from the lowest: compounds 2, 1, 4 and 3 (each within the scatter of the next).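

In this assay, the stereocentre at the saturated chain carbon was put to a direct test, giving a number 1 percentage points lower from compound 3 to compound 4 (within the scatter), so with iodo on the aromatic carbon, neither drawn configuration can be told apart from the other. The comparison isolates this single feature: the fact that compounds 3 and 4 differ only in the configuration as drawn The aromatic substituent can now also be compared within the S-drawn series, where iodo in place of methoxy gives a number 1 percentage points higher from compound 2 to compound 4 (within the scatter) and iodo in place of isopropyl gives no change at the digits printed from compound 1 to compound 4 (within the scatter).

On these data alone, it remains open whether the configuration would stay without a readable effect if an amine or a carboxylic acid stood on the aromatic carbon, or if a longer chain stood on the saturated chain carbon. As far as these compounds go, how these compounds behave at any other concentration also remains open.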